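The compounds below may be only part of what the source reports. "The series", "measured", "known", "first", "only" and "open" are said of these compounds alone.

Measured in a functional assay on the whole organism for inhibition, with Scenedesmus acutus as the target; a lower number here means a stronger inhibitor, a higher number a weaker inhibitor:
- compound 1 `CC(C)OC(=O)c1cc(N2C(=O)C3=C(CCCC3)C2=O)ccc1Cl`: 1230 nM
- compound 2 `CCC(C)OC(=O)c1cc(N2C(=O)C3=C(CCCC3)C2=O)ccc1Cl`: 1100 nM

Compound 2 stands level with compound 1, since the two lie within the scatter of each other. Compound 3 `CCCCCCCCOC(=O)c1cc(N2C(=O)C3=C(CCCC3)C2=O)ccc1Cl` carries octyl in place of sec-butyl on an oxygen next to a carbonyl group. Within the data shown here, only one measured step bears on this change, a 1.1-fold lower number from compound 1 to compound 2 (0.05 log units; within the scatter), and it concerns a far smaller alteration of the chain. Among the measured compounds shown here, no measured compound carries a chain as long as octyl, so no direction can be drawn from the data. The expected change is a 1.2-fold higher number from compound 2 to compound 3 (0.07 log units; within the scatter), with no step beyond the scatter anticipated. In this assay, compound 3 is estimated at 1300 nM, with an expected range of 300 nM to 5500 nM.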

Compound 3, half-maximal inhibitory concentration: > 100000 nM
Compound 3 gave a limit, no number (the forecaster's own chance of this, stated with the estimate: 5%); middle value at least 76-fold (1.88 log units) away from the limit.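

On an oxygen next to a carbonyl group, the chain proves able to matter in this assay: octyl in place of sec-butyl gives an at least 90-fold higher number from compound 2 to compound 3 (1.95 log units; beyond the scatter), and octyl in place of isopropyl gives an at least 81-fold higher number from compound 1 to compound 3 (1.91 log units; beyond the scatter). Isopropyl and sec-butyl had stayed within the scatter of each other, so the earlier pair showed no such sensitivity at this place. Compound 3 gives a limit of the assay, not a number: the limit of > 100000 nM in this assay, at which 1 of the 3 values shown sits.

The compounds shown leave open where between sec-butyl and octyl the rise sets in, for instance with a hexyl chain. They also leave open whether a carboxylic acid at this place would stay level with compound 1.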